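Urotensin-2 receptor series: amide in place of thienylmethyl

The source may hold more compounds than are shown below. What is called first, only, known or untested is meant among the compounds shown, and "the series" means these compounds.

Compound 1 `CCN1CCN(c2cccc3c2CN([C@H](CCCNCc2cccs2)c2ccc(OC)c(OC)c2)C3=O)CC1` is the reference point of this set. In an assay on RMS13 cells for displacement of a labelled ligand from Urotensin-2 receptor (Homo sapiens), read by scintillation proximity assay (on this read-out lower numbers stand for stronger inhibition and higher numbers for weaker inhibition), compound 1 gives 18 nM, the lowest of the three numbers recorded. Compound 2 `COc1ccc([C@@H](CCCN(C)S(=O)(=O)c2cccs2)N2Cc3c(cccc3N3CCN(C4CC4)CC3)C2=O)cc1OC` gives 59 nM in this assay, a higher number than compound 1 by a margin beyond the usual scatter, and compound 3 `CCN1CCN(c2cccc3c2C(=O)N([C@H](CCCNS(=O)(=O)c2cn(C)c(C)n2)c2ccc(OC)c(OC)c2)C3=O)CC1` gives 97 nM, further still from compound 1. For the measured compounds named here, the two companions thus sit clearly on the weaker side of compound 1, and no single-point step between any of the measured pairs is available to calibrate the effect of changing the substituent on the amine nitrogen.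

Compound 4 `CCN1CCN(c2cccc3c2CN([C@H](CCCNC(=O)c2c(C)n[nH]c2C)c2ccc(OC)c(OC)c2)C3=O)CC1` has not yet been measured in this assay. It differs from compound 1 in one place: (3,5-dimethyl-1H-pyrazol-4-yl)carbonyl in place of (thiophen-2-yl)methyl on an amine nitrogen. Since both measured companions with other substituents in this region give higher numbers than compound 1, a step from compound 1 to compound 4 of a 3.3-fold higher number from compound 1 to compound 4 (0.52 log units; beyond the scatter) towards a weaker result is expected, a loss beyond the scatter but not a large one. Compound 4 is therefore estimated at 60 nM in this assay, within a range of 20 nM to 180 nM.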

Compound 4, inhibition constant: 11 nM
Compound 4: the middle estimate sits 5.5-fold (0.74 log units) above what was measured; the whole stated range lies above it.
By their numbers in this assay, from the lowest: compounds 4 and 1 (each within the scatter of the next); then compounds 2 and 3 (each within the scatter of the next).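

In this assay, for the compounds shown here, (3,5-dimethyl-1H-pyrazol-4-yl)carbonyl in place of (thiophen-2-yl)methyl on the amine nitrogen gives a 1.6-fold lower number from compound 1 to compound 4 (0.21 log units; within the scatter), the only single-place step in the set, so this position takes the amide with no difference outside the scatter. The exchange adds a hydrogen-bond donor, a second ring hetero atom and a double bond outside the ring, and the two compounds still read alike. Nothing shown explains this equivalence.

As far as these compounds go, it remains open whether the ring or the carbonyl carries the result; an acetyl or benzoyl group on the same nitrogen, or (3,5-dimethyl-1H-pyrazol-4-yl)methyl, would separate the two. Also open, from the compounds shown here alone, is how the amide responds to a methyl group on its nitrogen.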